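Phenethyl versus benzyl on the sulfur linker: cytotoxicity notes

A few compounds are considered here, and "the series" means these few. Any claim that something is new, unique, unknown or untested is made for them only; others in the source may bear on it.

Compound 1 `C=Cc1ccc(-c2cc(C)c3ncc(CSCCc4ccccc4)n3c2)cc1` and compound 2 `C=Cc1ccc(-c2cc(C)c3ncc(CSCc4ccccc4)n3c2)cc1` share one core and differ by phenyl in place of benzyl on a saturated chain carbon bound to a sulfur. In an ADME assay on HEL cells (Homo sapiens) for cytotoxicity, with a stated time of 3 days (a lower number here means that less compound is tolerated, a higher number that more compound is tolerated), compound 1 gives 20 ug/mL. For compound 2 the assay reports only a limit, >= 100 ug/mL, so its number is not fixed. The step of an at least 5.0-fold higher number from compound 1 to compound 2 (0.69 log units; beyond the scatter) is therefore read against (the limit of >= 100 ug/mL in this assay, at which 1 of the 3 values shown sits), which sets the ceiling of what can be seen. Compound 3 `Cc1cc(-n2cccc2)c2ncc(CSCCc3ccccc3)n2c1` carries a different core; how the two cores differ is not broken down here. In this assay compound 3 gives 100 ug/mL, which beside compound 1 stands higher by a margin beyond the scatter. Compound 3 and compound 2 cannot be ordered against each other, as compound 2 has only a limit.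

Compound 4 `Cc1cc(-n2cccc2)c2ncc(CSCc3ccccc3)n2c1` relates to compound 3 by phenyl in place of benzyl on a saturated chain carbon bound to a sulfur, the same change already made between compound 1 and compound 2, at the same place. The expectation for compound 4 rests on two things: the step of an at least 5.0-fold higher number from compound 1 to compound 2 (0.69 log units; beyond the scatter) moved the value at least modestly upward, and compound 3 already sits at 100 ug/mL. Compound 4 is expected to give about 100 ug/mL, with a range from 50 ug/mL to 200 ug/mL. The expected step of no change at the digits printed from compound 3 to compound 4 (within the scatter) is small, chiefly since the assay ceiling leaves little room above compound 3, and a limit rather than a number is the likelier report.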

Compound 4, minimum cytotoxic concentration: 100 ug/mL
The estimate for compound 4 equals the measured number at the digits printed; the range from low to high includes it.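

Notes on carrying the change across cores

In this assay, phenyl in place of benzyl on a saturated chain carbon bound to a sulfur gives no change at the digits printed from compound 3 to compound 4 (within the scatter) on the core of compound 3, so the size of the step does not carry over unchanged from the core of compound 1: the same change on two cores in this assay, an at least 5.0-fold higher number (0.69 log units; beyond the scatter) from compound 1 to compound 2 and no change at the digits printed (within the scatter) from compound 3 to compound 4, at least 5.0-fold (0.69 log units) apart, beyond the scatter of two such steps.
Compound 2 is reported only as a limit, so the earlier step is a bound and not a fixed size, and the comparison of the two steps has to be read with that in mind: the limit of >= 100 ug/mL in this assay, at which 1 of the 4 values shown sits.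
The two pairs show that the outcome of this change depends on the core in these compounds, but they do not show why the cores differ, and they give no rule for how the change would read on any further core.

The compounds shown all keep the sulfur linker with a phenethyl or benzyl group on it, which leaves open how a longer chain such as phenylpropyl, or an amine or a carboxylic acid on that chain, would read in this assay. As far as these compounds go, it also remains open whether the difference between the two steps would hold on a third core.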